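Adding propylcarbamoyl to compound 1

The source may hold more compounds than are shown below. What is called first, only, known or untested is meant among the compounds shown, and "the series" means these compounds.

Compound 1 (`CC[C@@H]1C(=O)N(C)c2cnc(-n3ccc4ccccc43)nc2N1C1CCCC1`): 17200 nM
Compound 2 (`CC[C@@H]1C(=O)N(C)c2cnc(Nc3ccc(S(=O)(=O)NCCCO)cc3)nc2N1C1CCCC1`): 363 nM

In a functional assay on MCF7 cells (Homo sapiens) for antiproliferative activity, read by CCK-8 assay, with a stated time of 72 h (a higher number here means a weaker inhibitor of growth, a lower number a stronger inhibitor of growth), compound 1 has the higher number of the two, and the gap to compound 2 lies beyond the scatter. Compound 3 (`CCCNC(=O)c1ccc2c(ccn2-c2ncc3c(n2)N(C2CCCC2)[C@H](CC)C(=O)N3C)c1`) keeps the core of compound 1 but has propylcarbamoyl in place of hydrogen on an aromatic carbon. For the measured compounds named here, no measured pair tests this change. Going by the values given here, compound 2 (at 363 nM) shows only that the shared core can reach much lower numbers, so a moderate drop beyond the scatter in this assay is expected. The expected change is a 5.7-fold lower number from compound 1 to compound 3 (0.76 log units; beyond the scatter) (an estimate). Compound 3 is estimated at 3000 nM (range 600 nM to 13000 nM).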

Compound 3, concentration for 50% growth inhibition: 592 nM
Beside the measured number, compound 3's estimate is 5.1-fold (0.70 log units) above it; the whole stated range lies above it.
By their numbers in this assay, from the lowest: compounds 2 and 3 (each within the scatter of the next); then compound 1.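

In this assay placing propylcarbamoyl on this aromatic carbon gives a 29-fold lower number from compound 1 to compound 3 (1.46 log units; beyond the scatter) in a single change. For the compounds shown here, this is the first sign that this carbon, which carries only hydrogen in compound 1, can hold a substituent and that a change here alone can lower the number by a large step. Nothing at hand explains the gain. From the compounds shown here alone, it remains open how much depends on the propyl chain and how much on the carbonyl and its nitrogen. A methylcarbamoyl group, a longer chain or a carboxylic acid on the same carbon would help separate these parts.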